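The source may report more compounds than this note shows. Statements on the series, on what has been measured and on what is new or still open speak of the compounds shown alone.

Compound 2 `CC(=O)c1ccc(NC(=O)C(CC(C)C)N(C(=O)c2ccccc2)S(=O)(=O)c2ccc([N+](=O)[O-])cc2)cc1` stands as the higher of the two numbers in hand. In a functional assay for inhibition, read by spectrophotometry, with a stated time of 20 min, tested at 2 mg/mL (on this read-out lower numbers stand for a weaker effect and higher numbers for a stronger effect at the one concentration tested), compound 2 gives 54.2%, whereas compound 1 `CC(=O)c1ccc(NC(=O)CN(C(=O)c2ccccc2)S(=O)(=O)c2ccc([N+](=O)[O-])cc2)cc1` gives 20.6%. Going by the values given here, the single measured step, a number 33.6 percentage points higher from compound 1 to compound 2 (beyond the scatter), concerns isobutyl in place of hydrogen on a saturated chain carbon bound to an amide-type nitrogen and a carbonyl carbon. Compound 3 `CC(=O)c1ccc(NC(=O)C(CC(C)C)N(C(=O)c2ccccc2)S(=O)(=O)c2ccccc2)cc1` differs from compound 2 at a different place, namely (hydrogen in place of nitro on an aromatic carbon), on an aromatic carbon of a six-membered aromatic ring of carbon only, para to a large group. Among the compounds with values here, no measured step touches this part of the molecule, so the data give no direction for it. The expectation is therefore a modest shift for compound 3, with a step of a number 10.2 percentage points lower from compound 2 to compound 3 (beyond the scatter) expected. Compound 3 is estimated at 44%, within an expected range of 22% to 64%.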

Compound 3, a percentage reported as inhibition, at one concentration (the size of the read-out at that concentration, not a potency): 33.7%
Compound 3: middle estimate off by 10.3 percentage points, on the high side; the range from low to high includes it.
By their numbers in this assay, from the lowest: compound 1; then compound 3; then compound 2.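

Replacing nitro with hydrogen on an aromatic carbon, para to a large group, while keeping the isobutyl group, gives a number 20.5 percentage points lower from compound 2 to compound 3 (beyond the scatter) in this assay. This shows that the read-out depends on this position as well as on the chain carbon changed in the earlier step. With the isobutyl group present, 4-nitrophenyl therefore gives the higher number and phenyl the lower one, but nothing available explains this difference.

Going by these compounds, whether an amine, a methoxy group or a chlorine atom at this same place would give a number nearer that of compound 2 or of compound 3 remains open. On these data alone, it is also open whether replacing nitro with hydrogen would lower the number in the same direction in compound 1, which carries hydrogen in place of isobutyl.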